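Removing a chloro group from a weakly cytotoxic dihydropyridine series

This account rests on a few compounds, and the source may have more. Where it says the series, first, only, none or still open, it means among the compounds named here.

Of the compounds shown here, three from this set share one core and have been tested in a functional assay on Ehrlich cells (Mus musculus) for cytotoxicity; a higher number here means a weaker inhibitor, a lower number a stronger inhibitor. Compound 1 `COc1cc(N2C(N)=C(C#N)C(c3ccc(OC)c4ccccc34)C3=C2CC(C)(C)CC3=O)cc(OC)c1OC` gives "not active" (no number reported) in this assay. For the measured compounds named here, compound 2 `COc1cc(N2C(N)=C(C#N)C(c3ccc([N+](=O)[O-])cc3)C3=C2CC(C)(C)CC3=O)cc(OC)c1OC` gives 25000 nM in this assay, the only numerical value among the three. Compound 3 `COc1cc(N2C(N)=C(C#N)C(c3ccccc3Cl)C3=C2CC(C)(C)CC3=O)cc(OC)c1OC` gives "not active" (no number reported) in this assay, so no number places it on the scale, and compound 1 stands in the same situation. Going by the values given here, no step between two measured compounds can therefore be stated.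

Compound 4 `COc1cc(N2C(N)=C(C#N)C(c3ccccc3)C3=C2CC(C)(C)CC3=O)cc(OC)c1OC` differs from compound 3 in one place: hydrogen in place of chloro on an aromatic carbon. With no measured step of this kind in the set, the size of the step in this assay cannot be drawn from the data; a change of no more than the usual scatter is expected, in no particular direction, with a real chance that compound 4 again yields no number at all. On that basis compound 4 is expected to give 40000 nM in this assay, within a range of 12000 nM to 150000 nM.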

Compound 4, half-maximal inhibitory concentration: "not active" (no number reported)
No number was reported for compound 4, and the estimate cannot be compared.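

For the compounds shown here, neither compound 3 nor compound 4 has a number in this assay, so no step from 2-chlorophenyl to phenyl can be read. Nothing measured here offers an explanation. The compounds shown leave open whether removing the chloro group alters cytotoxicity at all.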